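The source may hold more compounds than are shown below. What is called first, only, known or untested is meant among the compounds shown, and "the series" means these compounds.

Working notes on a small series built on a shared core, so far two members: compound 1 `Cc1c(C(=O)Nc2ccccc2F)cnn1-c1ccc(F)cc1` and compound 2 `Cc1c(C(=O)Nc2ccc(C(F)(F)F)cc2)cnn1-c1ccc([N+](=O)[O-])cc1`. Both have been run in a functional assay with Homo sapiens as the target; a lower number here means a stronger inhibitor, a higher number a weaker inhibitor. In this assay compound 1 gives 4000 nM and compound 2 gives 5700 nM. Within the data shown here, the two numbers lie within the usual scatter of each other, so on what is measured compound 2 cannot be told apart from compound 1, and no step between measured compounds is recorded that would bear on the change below. Compound 3 `Cc1c(C(=O)Nc2ccc(C(F)(F)F)cc2)cnn1-c1cccc(Cl)c1Cl` has not yet been measured. It departs from compound 2 in one place: 2,3-dichlorophenyl in place of 4-nitrophenyl on an aromatic nitrogen. Among the measured compounds shown here, with no measured pair carrying this kind of change, the step is expected to stay within the scatter, with no firm direction; the expected step is a 1.3-fold lower number from compound 2 to compound 3 (0.10 log units; within the scatter). For compound 3 in this assay the estimate is 4500 nM, with a range from 1200 nM to 16000 nM.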

Compound 3, half-maximal inhibitory concentration: 1600 nM
For compound 3 the middle estimate is 2.8-fold (0.45 log units) above the measured one; measured number inside the range.
By their numbers in this assay, from the lowest: compound 3; then compounds 1 and 2 (each within the scatter of the next).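

In this assay, among these compounds, the group on the aromatic nitrogen can clearly move the number: 2,3-dichlorophenyl in place of 4-nitrophenyl gives a 3.6-fold lower number from compound 2 to compound 3 (0.55 log units; beyond the scatter), the only recorded step and one that lies beyond the scatter, though it is modest. The rest of the structure is the same in both compounds, so this step belongs to this one position, and the 4-nitrophenyl group is not required for activity at this level. Nothing on hand accounts for the step, and whether it comes from losing the nitro group or from gaining the chlorines cannot be separated.

On these data alone, it remains open whether both chlorines are needed or a single chlorine on the phenyl ring would serve. Also open, as far as these compounds go, is how a methoxy group on that ring, or a pyridine ring in place of the phenyl, would read here.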